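This account rests on a few compounds, and the source may have more. Where it says the series, first, only, none or still open, it means among the compounds named here.

Compound 1, `Cc1cccnc1-c1ccc(C(=O)Nc2ccc(F)cc2)cc1`: in a functional assay for antagonist activity at transient receptor potential cation channel subfamily V member 1 (Rattus norvegicus) (on this read-out lower numbers stand for stronger inhibition and higher numbers for weaker inhibition), compound 1 reaches only a limit, > 4000 nM.
Compound 2, `Cc1cccnc1-c1ccc(C(=O)Nc2ccc(C(F)(F)F)cc2)cc1`: in this assay compound 2 gives 81 nM.
Compound 3, `CC(C)(C)c1ccc(NC(=O)c2ccc(-c3ncccc3F)cc2)cc1`: in this assay compound 3 gives 1 nM.

Among the two numbers shown, compound 3 has the lowest; the step from compound 2 to it is well beyond the scatter. Compound 4, `CC(C)(C)c1ccc(NC(=O)c2ccc(-c3ncccc3NS(C)(=O)=O)cc2)cc1`, differs from compound 3 by methanesulfonamido in place of fluoro on an aromatic carbon. For the measured compounds named here, the only measured step, an at least 49-fold lower number from compound 1 to compound 2 (1.69 log units; beyond the scatter), concerns a different place in the shared core and a different pair of groups, so it gives no direct guide to this change. Going by the values given here, since no measured step touches the ring carrying the fluoro, the expectation rests on the size of the change alone: a large group is expected in place of a small one, and compound 4 is estimated to come out weaker, with a step of a 30-fold higher number from compound 3 to compound 4 (1.48 log units; beyond the scatter). Compound 4 is therefore expected at about 30 nM, somewhere between 3 nM and 300 nM.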

Compound 4, half-maximal inhibitory concentration: 35 nM
For compound 4 the middle estimate is 1.2-fold (0.07 log units) below the measured one, within the range that was stated.
By their numbers in this assay, from the lowest: compound 3; then compound 4; then compound 2. At a limit, above all of these: compound 1.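

In this assay, for the compounds shown here, methanesulfonamido in place of fluoro gives a 35-fold higher number from compound 3 to compound 4 (1.54 log units; beyond the scatter), the first measured change on this aromatic carbon, two atoms from the ring nitrogen. Even so, compound 4 still gives 35 nM, so inhibition survives this much larger group at this position. Nothing given here accounts for the size of this step.

With only two groups shown at this position, it stays open whether the step follows the number of heavy atoms or this particular group. An amine or a methyl group on the same carbon could help to separate the two.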